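Replacing the aryl on the aromatic nitrogen with an ester chain

A few compounds are considered here, and "the series" means these few. Any claim that something is new, unique, unknown or untested is made for them only; others in the source may bear on it.

Among the compounds with values here, compound 3 `Cc1ccccc1-c1nn(-c2ccc(Br)cc2)cc1CNCCN1CCN(C)CC1` is the only member of this set with a number in an ADME assay on Huh-7 cells (Homo sapiens) for cytotoxicity; a higher number here means that more compound is tolerated, a lower number that less compound is tolerated: compound 3 gives 9600 nM. Compound 1 `Cc1ccccc1-c1nn(-c2cc(F)ccc2F)cc1CNCCN1CCN(C)CC1` reaches only the limit of this assay, > 20000 nM. Compound 2 `Cc1ccc(-n2cc(CNCCN3CCN(C)CC3)c(-c3ccccc3C)n2)c(C)c1` likewise reaches only the limit, > 20000 nM. The steps of an at least 2.0-fold lower number from compound 1 to compound 3 (0.31 log units; beyond the scatter) and an at least 2.0-fold lower number from compound 2 to compound 3 (0.31 log units; beyond the scatter) both run from the limit of > 20000 nM in this assay, at which 2 of the 3 values shown sit, down to that single number, while the step that the two limits leave unreadable from compound 1 to compound 2 gives no size. Compound 4 `CCOC(=O)Cn1cc(CNCCN2CCN(C)CC2)c(-c2ccccc2C)n1` differs from compound 3 by (ethoxycarbonyl)methyl in place of 4-bromophenyl on an aromatic nitrogen. Within the data shown here, no measured step swaps the aryl for a non-aromatic chain; the two measured aryl changes only moved between the limit and compound 3. The expected step of a 1.9-fold higher number from compound 3 to compound 4 (0.27 log units; within the scatter) is therefore a modest return toward the limit. Compound 4 is estimated at 18000 nM, range 8000 nM to 40000 nM.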

Compound 4, half-maximal cytotoxic concentration: > 20000 nM
Compound 4: no number, only a limit; the forecaster's own chance of this, stated with the estimate: 55%; middle value at least 1.1-fold (0.04 log units) from the limit.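

Earlier steps only exchanged one aryl for another on the aromatic nitrogen, whereas (ethoxycarbonyl)methyl, with no ring, gives an at least 2.0-fold higher number from compound 3 to compound 4 (0.31 log units; beyond the scatter) in this assay. Compound 4 gives only a limit, so the steps to it from compound 1 and compound 2 cannot be read. Among the groups shown, only 4-bromophenyl gives a number, and the rest of the set sits at the ceiling: the limit of > 20000 nM in this assay, at which 3 of the 4 values shown sit.

On these data alone, how far these compounds lie beyond that limit stays open. Also open, as far as these compounds go, is whether a carboxylic acid, an amine or a longer chain on this nitrogen would stay at the limit.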